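Halogen swap on the ester-bearing ring: compound 4

This account rests on a few compounds, and the source may have more. Where it says the series, first, only, none or still open, it means among the compounds named here.

Measured so far, in a functional assay on cells (T-cell, Mus musculus, strain BALB/c) for inhibition, read by MTT assay, with a stated time of 72 h; a higher number here means a weaker inhibitor, a lower number a stronger inhibitor:
compound 1 `COC(=O)c1c(F)cccc1OC(=O)COc1cc(O)c2c(=O)cc(-c3ccccc3)oc2c1` gives 40300 nM
compound 2 `COC(=O)c1c(Br)cccc1OC(=O)COc1cc(O)c2c(=O)cc(-c3ccccc3)oc2c1` gives 41700 nM
compound 3 `COC(=O)c1cc(Br)ccc1OC(=O)COc1cc(O)c2c(=O)cc(-c3ccccc3)oc2c1` gives 780 nM

Compound 3 and compound 2 carry the same atoms joined differently; the difference is a group of 11 heavy atoms (8 carbon, 2 oxygen, 1 bromine; one six-membered aromatic ring of carbon only) in place of a group of 11 heavy atoms (8 carbon, 2 oxygen, 1 bromine; one six-membered aromatic ring of carbon only), on an oxygen next to a carbonyl group. That rearrangement gives a 53-fold lower number from compound 2 to compound 3 (1.73 log units; beyond the scatter), and likewise a 52-fold lower number from compound 1 to compound 3 (1.71 log units; beyond the scatter).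

Compound 4 `COC(=O)c1cc(F)ccc1OC(=O)COc1cc(O)c2c(=O)cc(-c3ccccc3)oc2c1` is not yet measured. It differs from compound 3 by fluoro in place of bromo on an aromatic carbon. The same kind of change, (fluoro in place of bromo on an aromatic carbon), has been made once already, giving a 1.0-fold lower number from compound 2 to compound 1 (0.01 log units; within the scatter). The place is not identical: in compound 1 the fluoro sits ortho to a methoxycarbonyl group and meta to a large group, whereas in compound 4 it sits meta to a methoxycarbonyl group and para to a large group.

Compound 4 is expected to stay near compound 3, because the earlier swap gave a 1.0-fold lower number from compound 2 to compound 1 (0.01 log units; within the scatter); the expected step is a 1.2-fold higher number from compound 3 to compound 4 (0.06 log units; within the scatter). Compound 4 is therefore estimated at 900 nM, between 300 nM and 2700 nM.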

Compound 4, half-maximal inhibitory concentration: 6820 nM
Beside the measured number, compound 4's estimate is 7.6-fold (0.88 log units) below it; measured number outside the range, above it.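

In this assay, fluoro in place of bromo on an aromatic carbon gives an 8.7-fold higher number from compound 3 to compound 4 (0.94 log units; beyond the scatter). This swap does not carry a fixed step from one core to another: the same change on two cores in this assay, a 1.0-fold lower number (0.01 log units; within the scatter) from compound 2 to compound 1 and an 8.7-fold higher number (0.94 log units; beyond the scatter) from compound 3 to compound 4, 9.0-fold (0.96 log units) apart, beyond the scatter of two such steps
With fluoro on both sides, the different place on the ring gives a 5.9-fold lower number from compound 1 to compound 4 (0.77 log units; beyond the scatter), and the comparison with the bromo compound gives a 6.1-fold lower number from compound 2 to compound 4 (0.79 log units; beyond the scatter), so the arrangement of compound 4 still keeps a lower number than either compound with the other arrangement. Two pairs show that the size of this swap depends on its setting here, but they give no general rule and no reason for the difference.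

On these data alone, it remains open whether chloro or iodo para to a large group would track compound 3 or compound 4. Also open, as far as these compounds go, is how a carboxylic acid in place of the methoxycarbonyl group would behave.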